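A few compounds are considered here, and "the series" means these few. Any claim that something is new, unique, unknown or untested is made for them only; others in the source may bear on it.

Compound 1 `CC(O)(CS(=O)(=O)c1cccc(C(F)(F)F)c1)C(=O)Nc1cccc(S(F)(F)(F)(F)F)c1`: 24600 nM
Compound 2 `CC(O)(CS(=O)(=O)c1ccccc1C(F)(F)F)C(=O)Nc1cccc(S(F)(F)(F)(F)F)c1`: 27700 nM

Both values come from a functional assay on CWR22R cells (Homo sapiens) for antiproliferative activity, read by propidium iodide staining, with a stated time of 96 h; a lower number here means a stronger inhibitor, a higher number a weaker inhibitor. Among the measured compounds shown here, compound 2, at 27700 nM, cannot be told apart from compound 1, and the series so far offers only this one pair.

Compound 3 `CC(O)(CS(=O)(=O)c1ccc(OC(F)(F)F)cc1)C(=O)Nc1cccc(S(F)(F)(F)(F)F)c1` has 4-(trifluoromethoxy)phenyl in place of 2-(trifluoromethyl)phenyl on a sulfonyl sulfur. For the measured compounds named here, only one measured step bears on this, and only in part: exchanging 3-(trifluoromethyl)phenyl for 2-(trifluoromethyl)phenyl gave a 1.1-fold higher number from compound 1 to compound 2 (0.05 log units; within the scatter). Going by the values given here, no measured compound carries a trifluoromethoxy group, so this expectation rests on thin evidence. On that single step, no change beyond the scatter is expected in this assay, and no direction can be assigned.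

The expected step is a 1.2-fold lower number from compound 2 to compound 3 (0.06 log units; within the scatter).

For compound 3 the estimated value is 24000 nM, with an expected range of 9000 nM to 55000 nM.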

Compound 3, half-maximal inhibitory concentration: 31200 nM
The estimate for compound 3 lay 1.3-fold (0.11 log units) below the measured number, and the stated range covers the measured number.
By their numbers in this assay, from the lowest: compounds 1, 2 and 3 (each within the scatter of the next).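

Replacing the aryl group on the sulfonyl sulfur with 4-(trifluoromethoxy)phenyl gives, in this assay, a 1.1-fold higher number from compound 2 to compound 3 (0.05 log units; within the scatter) and a 1.3-fold higher number from compound 1 to compound 3 (0.10 log units; within the scatter). The earlier pair compared only two placements of trifluoromethyl on the phenyl; this result extends the same flat reading to a different substituent, one that brings an oxygen and a hydrogen-bond acceptor, so the three aryl groups cannot be separated in this assay. No evidence is available to explain this flat reading.

On these data alone, whether any group at this place can move the number beyond the scatter remains open, for example a phenyl carrying an amine or a carboxylic acid. All three compounds share the rest of the core, so they say nothing about changes elsewhere in it.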